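The source may hold more compounds than are shown below. What is called first, only, known or untested is meant among the compounds shown, and "the series" means these compounds.

In a functional assay on KM12 cells (Homo sapiens) for antiproliferative activity (on this read-out lower numbers stand for stronger inhibition of growth and higher numbers for weaker inhibition of growth), compound 1 `Cc1cc(-c2nc3ccccc3s2)ccc1N` gives > 100000 nM, which is a limit of the assay and not a number. Compound 2 `Oc1ccc(-c2nc3ccccc3s2)cc1O` gives 15600 nM, and compound 3 `COc1ccc(-c2nc3cc(F)ccc3s2)cc1` gives 24600 nM, so compound 3 stands within the scatter of compound 2. Compound 4 `COc1ccc(-c2nc3cc(F)ccc3s2)cc1Cl` carries one change from compound 3: chloro in place of hydrogen on an aromatic carbon, ortho to a methoxy group and meta to a large group (chloro in place of hydrogen on an aromatic carbon). No measured pair among these compounds shows what such a swap does, so any forecast is loose. The expected move is a sizeable one towards stronger inhibition of growth, an estimated 8.2-fold lower number from compound 3 to compound 4 (0.91 log units; beyond the scatter). Compound 4 is expected to give about 3000 nM, with an estimated range of 50 nM to 40000 nM.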

Compound 4, concentration for 50% growth inhibition: 7050 nM
Compound 4: middle estimate off by 2.4-fold (0.37 log units), on the low side; low and high end bracket the measured number.
By their numbers in this assay, from the lowest: compound 4; then compounds 2 and 3 (each within the scatter of the next). At a limit, above all of these: compound 1.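

Chloro in place of hydrogen on this aromatic carbon, ortho to a methoxy group, is the first single change that can be read in this assay and gives a 3.5-fold lower number from compound 3 to compound 4 (0.54 log units; beyond the scatter) in the direction of stronger inhibition of growth. This position therefore takes a chlorine atom without loss of growth inhibition. Nothing measured among these compounds explains the size of this step. One swap at one position leaves open what a bromo group, a nitrile or a carboxylic acid on the same carbon would do. On these data alone, whether chloro acts the same way on the core of compound 2 also stays open.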